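This account rests on a few compounds, and the source may have more. Where it says the series, first, only, none or still open, it means among the compounds named here.

Compound 1 `COc1ccc(-c2ccc3c(NCCCNCc4cccc(OC)c4O)ccnc3c2)cc1`: 237 10^-6 cm/s
Compound 2 `COc1ccc(-c2ccc3c(NCCCNCc4cc(F)ccc4OC)ccnc3c2)cc1`: 237 10^-6 cm/s

In an ADME assay for permeability, using PAMPA, with a stated time of 30 min, at pH 7.4 (a higher number here means that the compound crosses the layer faster, a lower number that the compound crosses the layer more slowly), compound 1 gives 237 10^-6 cm/s and stands level with compound 2, which gives 237 10^-6 cm/s. Among the measured compounds shown here, the one measured step, no change at the digits printed from compound 1 to compound 2 (within the scatter), swaps the group on the saturated chain carbon and stays within the scatter. Compound 3 `COc1cccc(CNCCCNc2ccnc3cc(Cc4ccc(F)cc4Cl)ccc23)c1O` differs from compound 1 by 2-chloro-4-fluorobenzyl in place of 4-methoxyphenyl on an aromatic carbon. For the measured compounds named here, no measured step touches that part of the core, so nothing bears directly on this change. Compound 3 is therefore expected to show a 1.0-fold lower number from compound 1 to compound 3 (0.01 log units; within the scatter), with no step beyond the scatter. The estimate for compound 3 is 230 10^-6 cm/s, in a range from 120 10^-6 cm/s to 420 10^-6 cm/s.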

Compound 3, apparent permeability: 23 10^-6 cm/s
Compound 3: middle estimate off by 10-fold (1.00 log units), on the high side; measured number below the stated range.
By their numbers in this assay, from the lowest: compound 3; then compounds 1 and 2 (each within the scatter of the next).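

In this assay, among the compounds shown here, the aromatic carbon of the shared core proves to be a place where a change counts: 2-chloro-4-fluorobenzyl in place of 4-methoxyphenyl gives a 10-fold lower number from compound 1 to compound 3 (1.01 log units; beyond the scatter) and so moves the number beyond the scatter, unlike the one earlier step, made on the saturated chain carbon. No measurement shown here accounts for this drop. The compounds shown leave open whether the benzyl link or the two halogens carries the step, which a 4-methoxybenzyl group at this place would separate. They also leave open whether the step holds with the 5-fluoro-2-methoxyphenyl group of compound 2 on the chain.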